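This account rests on a few compounds, and the source may have more. Where it says the series, first, only, none or still open, it means among the compounds named here.

Working notes on the series. The shared core of compound 1 `CC1(C)Oc2ccc(C#N)cc2[C@@H](/N=C(\NC#N)Sc2ccccc2)[C@@H]1O` carries a phenylsulfanyl on a carbon with a double bond to nitrogen. Among the measured compounds shown here, in a functional assay (aorta) with Rattus norvegicus as the target (a higher number here means a weaker inhibitor, a lower number a stronger inhibitor), compound 1 gives 4900 nM, the higher of the two numbers so far; compound 2 `COC(=O)c1cn([C@@H]2c3cc(C#N)ccc3OC(C)(C)[C@H]2O)c2ccccc12` gives 500 nM in this assay, a gap beyond the scatter. Compound 3 `CSc1cccc(N/C(=N/[C@@H]2c3cc(C#N)ccc3OC(C)(C)[C@H]2O)NC#N)c1` is unmeasured; it differs from compound 1 by (3-(methylsulfanyl)phenyl)amino in place of phenylsulfanyl on a carbon with a double bond to nitrogen. Without any measured step of this kind, the step from compound 1 to compound 3 is expected to be an 8.2-fold lower number from compound 1 to compound 3 (0.91 log units; beyond the scatter), toward a lower number. Compound 3 is estimated at 600 nM, with a range from 120 nM to 3000 nM.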

Compound 3, half-maximal inhibitory concentration: 1400 nM
Compound 3: the middle estimate sits 2.3-fold (0.37 log units) below what was measured, within the range that was stated.
By their numbers in this assay, from the lowest: compound 2; then compound 3; then compound 1.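

In this assay, among the compounds shown here, having (3-(methylsulfanyl)phenyl)amino in place of phenylsulfanyl on a carbon with a double bond to nitrogen gives a 3.5-fold lower number from compound 1 to compound 3 (0.54 log units; beyond the scatter) and provides the first readable step at this position. The entering group adds a nitrogen and a hydrogen-bond donor as well as methylsulfanyl, and this single step cannot separate their contributions. No measured evidence bears on the cause of the step.

As far as these compounds go, it remains open whether unsubstituted phenylamino would account for the step. A saturated cyclohexylamino on the same carbon is also untested in these compounds.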